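Para Substituent Swap on a Thiazolylidene Hydrazide Series

The source may report more compounds than this note shows. Statements on the series, on what has been measured and on what is new or still open speak of the compounds shown alone.

Measured compounds:
Compound 1, `Cc1nnc(SCC(=O)N/N=c2/scc(-c3ccc(F)cc3)n2-c2ccccc2)s1`: 50.1%
Compound 2, `Cc1nnc(SCC(=O)N/N=c2/scc(-c3ccc(Cl)cc3)n2-c2ccccc2)s1`: 53.3%

In a functional assay on C6 cells (Rattus norvegicus) for cytotoxicity, read by MTT assay, with a stated time of 24 h, tested at 25 ug/mL (a lower number here means a stronger effect, a higher number a weaker effect of the compound at the concentration tested), compound 2 stands highest of the two numbers, though its step from compound 1, a number 3.2 percentage points higher from compound 1 to compound 2 (within the scatter), is within the scatter. Compound 3, `COc1ccc(-c2cs/c(=N/NC(=O)CSc3nnc(C)s3)n2-c2ccccc2)cc1`, is not yet measured. It differs from compound 2 by methoxy in place of chloro on an aromatic carbon. Among the compounds with values here, the only step known, chloro in place of fluoro, was small and within the scatter; no measured step covers methoxy in place of chloro. Compound 3 is therefore expected to move by a number 1.3 percentage points lower from compound 2 to compound 3 (within the scatter), nothing beyond the scatter. Compound 3 is estimated at 52%, between 38% and 66%.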

Compound 3, a percentage reported as activity, at one concentration (the size of the read-out at that concentration, not a potency): 42.6%
Beside the measured number, compound 3's estimate is 9.4 percentage points above it; low and high end bracket the measured number.
By their numbers in this assay, from the lowest: compounds 3, 1 and 2 (each within the scatter of the next, the first and the last beyond it).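

In this assay, within the data shown here, methoxy in place of chloro gives a number 10.7 percentage points lower from compound 2 to compound 3 (beyond the scatter) and is the first step at this position to pass the scatter, so the para substituent can alter the read-out at the concentration tested. Methoxy in place of fluoro gives a number 7.5 percentage points lower from compound 1 to compound 3 (within the scatter) and so separates the methoxy compound clearly only from the chloro compound. Nothing available explains this shift.

Going by these compounds, it remains open whether an amine, a hydroxyl or a longer ether such as ethoxy at this position would lower the number further. A single concentration also shows only a stronger or weaker effect at that concentration and leaves the effect of these compounds at other concentrations unsettled.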